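This account rests on a few compounds, and the source may have more. Where it says the series, first, only, none or still open, it means among the compounds named here.

Measured compounds in a functional assay on MDA-MB-231 cells (Homo sapiens) for cytotoxicity, read by MTT assay, with a stated time of 24 h; a lower number here means a stronger inhibitor, a higher number a weaker inhibitor:
- compound 1, `Cc1cc(O)c(C(=O)/C=C/c2ccccc2)c(-c2ccccc2)c1C(=O)/C=C/c1ccccc1`, compound 1 gives 8500 nM
- compound 2, `Cc1cc(O)c(C(=O)/C=C/c2ccccc2)c(-c2ccc(Br)cc2)c1C(=O)/C=C/c1ccccc1`, compound 2 gives 8000 nM
- compound 3, `Cc1cc(O)c(C(=O)/C=C/c2ccc(OCc3ccccc3)cc2)c(-c2ccccc2)c1C(=O)/C=C/c1ccc(OCc2ccccc2)cc1`, compound 3 gives 10000 nM

The three measured values in this assay sit close together; none of the gaps between them goes beyond the usual scatter. The difference between compound 1 and compound 2 is bromo in place of hydrogen on an aromatic carbon, and that step amounts to a 1.1-fold lower number from compound 1 to compound 2 (0.03 log units; within the scatter), so the bromo group left the number essentially where it was.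

Compound 4, `Cc1cc(O)c(C(=O)/C=C/c2ccc(OCc3ccccc3)cc2)c(-c2ccc(Br)cc2)c1C(=O)/C=C/c1ccc(OCc2ccccc2)cc1`, is not yet measured. The difference between the cores of compound 3 and compound 1 is not broken down here. Compound 3 and compound 4 differ by bromo in place of hydrogen on an aromatic carbon, the same change as that from compound 1 to compound 2, at the same kind of place.

Because compound 1 to compound 2 gave a 1.1-fold lower number from compound 1 to compound 2 (0.03 log units; within the scatter), the expected step in this assay is about a 1.1-fold lower number from compound 3 to compound 4 (0.05 log units; within the scatter). Compound 4 is estimated at 9000 nM, with the range 4500 nM to 18000 nM taken as the expectation.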

Compound 4, half-maximal inhibitory concentration: 20000 nM
Estimate against measurement, compound 4: 2.2-fold (0.35 log units) below; measured number above the stated range.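

In this assay, phenyl to 4-bromophenyl on the core of compound 3 gives a 2.0-fold higher number from compound 3 to compound 4 (0.30 log units; within the scatter). Within what these data can resolve, the step carries over from one core to the other, with no difference between the two cores: the same change on two cores in this assay, a 1.1-fold lower number (0.03 log units; within the scatter) from compound 1 to compound 2 and a 2.0-fold higher number (0.30 log units; within the scatter) from compound 3 to compound 4, 2.1-fold (0.33 log units) apart, within the scatter of two such steps. This does not show that the step is identical on both cores or that it would hold on a third, since two pairs in a single assay can only fail to separate the steps.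

Still open, from the compounds shown here alone, is whether another group in place of the bromo, such as a methoxy, an amine or a carboxylic acid, would give a step beyond the scatter. Also open, going by these compounds, is whether bromo behaves the same way on cores carrying a longer chain in place of the benzyloxy groups.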